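The source may report more compounds than this note shows. Statements on the series, on what has been measured and on what is new or still open speak of the compounds shown alone.

Of the compounds shown here, two have so far been measured in a functional assay on 143B cells (Homo sapiens) for inhibition, read by MTT assay, with a stated time of 72 h; on this read-out lower numbers stand for stronger inhibition and higher numbers for weaker inhibition. Compound 1 `O=C(CCC(=O)OCCCCCCSc1ccc([N+](=O)[O-])c2nonc12)Nc1ccccc1F` gives 3030 nM, and compound 2 `O=C(CCC(=O)OCCCCCCSc1ccc([N+](=O)[O-])c2nonc12)Nc1cccc(Cl)c1` gives 2890 nM. Within the data shown here, the only step between them, a 1.0-fold lower number from compound 1 to compound 2 (0.02 log units; within the scatter), shows that swapping one aromatic ring for another on the amide nitrogen hardly changes the number; compound 2 has the lowest of the two numbers, but the gap to compound 1 is within the scatter, so neither can be called stronger.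

Compound 3 `O=C(CCC(=O)N1CCCCC1)OCCCCCCSc1ccc([N+](=O)[O-])c2nonc12` differs from compound 2 in this way: piperidin-1-yl in place of (3-chlorophenyl)amino on a carbonyl carbon. Among the measured compounds shown here, no measured step in this assay covers a change of this kind, so the single known step gives no direct guide. The expectation for compound 3 is therefore a cautious one, with a wide range, and the estimated step of a 1.2-fold higher number from compound 2 to compound 3 (0.08 log units; within the scatter) lies close to the scatter. Compound 3 is expected to give about 3500 nM in this assay, with a likely range from 1200 nM to 10000 nM.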

Compound 3, half-maximal inhibitory concentration: 1900 nM
Beside the measured number, compound 3's estimate is 1.8-fold (0.27 log units) above it, and the stated range covers the measured number.
By their numbers in this assay, from the lowest: compounds 3, 2 and 1 (each within the scatter of the next).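

In this assay, piperidin-1-yl on the carbonyl carbon gives a 1.5-fold lower number from compound 2 to compound 3 (0.18 log units; within the scatter), and in place of the (2-fluorophenyl)amino group it gives a 1.6-fold lower number from compound 1 to compound 3 (0.20 log units; within the scatter). The earlier pair varied only the aromatic ring, whereas compound 3 has no aromatic ring in this group and no hydrogen-bond donor, yet it remains within the scatter of both anilide-type compounds, so neither feature is needed for a number in this range among these three compounds. No available evidence bears on this result.

Still open, as far as these compounds go, is whether the number would hold with a carboxylic acid at this carbonyl carbon, or with an open-chain amine such as dimethylamino in place of the ring. From the compounds shown here alone, the effect of a shorter or longer chain in the linker also remains open.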